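Swapping chloro for methoxy on the aromatic ring

The source may hold more compounds than are shown below. What is called first, only, known or untested is meant among the compounds shown, and "the series" means these compounds.

- compound 1 `C/C(=C\CC/C(C)=C/CC[C@@H]1[C@@]2(C)CCC(=O)C(C)(C)[C@H]2CC[C@@]1(C)O)CC/C=C(\C)C(=O)OCc1cn(-c2cccc([N+](=O)[O-])c2)nn1`: > 150000 nM (a limit)
- compound 2 `C/C(=C\CC/C(C)=C/CC[C@@H]1[C@@]2(C)CCC(=O)C(C)(C)[C@H]2CC[C@@]1(C)O)CC/C=C(\C)C(=O)OCc1cn(-c2cccc(C)c2)nn1`: 137000 nM
- compound 3 `C/C(=C\CC/C(C)=C/CC[C@@H]1[C@@]2(C)CCC(=O)C(C)(C)[C@H]2CC[C@@]1(C)O)CC/C=C(\C)C(=O)OCc1cn(-c2cccc(Cl)c2)nn1`: 103000 nM

In a functional assay on DU-145 cells (Homo sapiens) for antiproliferative activity, read by MTT assay, with a stated time of 48 h (a lower number here means a stronger inhibitor, a higher number a weaker inhibitor), compound 3 gives 103000 nM, within the scatter of compound 2 at 137000 nM. Compound 1 gives only a limit, > 150000 nM.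

Compound 4 `COc1cccc(-n2cc(COC(=O)/C(C)=C/CC/C(C)=C/CC/C(C)=C/CC[C@@H]3[C@@]4(C)CCC(=O)C(C)(C)[C@H]4CC[C@@]3(C)O)nn2)c1` carries methoxy in place of chloro on an aromatic carbon, meta to a large group (methoxy in place of chloro on an aromatic carbon). Three swaps at this place bear on it: a 1.3-fold lower number from compound 2 to compound 3 (0.12 log units; within the scatter), an at least 1.0-fold lower number from compound 1 to compound 2 (0.03 log units; that floor lies within the scatter) and an at least 1.4-fold lower number from compound 1 to compound 3 (0.16 log units; that floor lies within the scatter). All three lie within the scatter, so no step beyond the scatter is expected in this assay, in either direction. For compound 4 the expected value is 120000 nM, with an estimated range of 70000 nM to 180000 nM. That estimate means an expected 1.2-fold higher number from compound 3 to compound 4 (0.07 log units; within the scatter).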

Compound 4, half-maximal inhibitory concentration: > 150000 nM
Compound 4: a limit, no number; the forecaster's own chance of this, stated with the estimate: 20%; middle value at least 1.2-fold (0.09 log units) from the limit.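

In this assay compound 4, carrying methoxy, gives a limit and no number: > 150000 nM. The floors of the two readable steps, an at least 1.4-fold higher number from compound 3 to compound 4 (0.16 log units; that floor lies within the scatter) and an at least 1.0-fold higher number from compound 2 to compound 4 (0.03 log units; that floor lies within the scatter), lie within the scatter, so methoxy is not shown to differ from chloro or methyl at this position. The step between compound 1 and compound 4 cannot be read, and a second group at this position now stands at the limit: the limit of > 150000 nM in this assay, at which 2 of the 4 values shown sit.

Open, from the compounds shown here alone, is whether an amine or a carboxylic acid on this aromatic carbon would move the number beyond the scatter.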